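Replacing the 2-Cyanophenyl Group of Compound 1

This account rests on a few compounds, and the source may have more. Where it says the series, first, only, none or still open, it means among the compounds named here.

Measured so far:
compound 1 `CN(C)C(=O)c1cccnc1NCCCN1CCN(c2ccccc2C#N)CC1`: 10 nM
compound 2 `CN(C)C(=O)c1cccnc1NCCCN1CCN(c2ccccc2OCC(F)(F)F)CC1`: 15.9 nM
compound 3 `CN(C)C(=O)c1cccnc1NCCCN1CCN(c2ccccc2-c2ccccc2)CC1`: 63.1 nM

In a functional assay on aorta for antagonist activity at Alpha-1D adrenergic receptor (Rattus norvegicus) (on this read-out higher numbers stand for weaker binding and lower numbers for tighter binding), compound 1 gives 10 nM and holds the lowest of the three numbers. Its nearest neighbour is compound 2, separated by a 1.6-fold higher number from compound 1 to compound 2 (0.20 log units; within the scatter), a gap that does not count as a real change. Compound 3 lies furthest away, with a 6.3-fold higher number from compound 1 to compound 3 (0.80 log units; beyond the scatter), and the same ordering appears in a 4.0-fold higher number from compound 2 to compound 3 (0.60 log units; beyond the scatter).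

Compound 4 `COc1cc(O)ccc1N1CCN(CCCNc2ncccc2C(=O)N(C)C)CC1` has not yet been measured in this assay. It differs from compound 1 in one place: 4-hydroxy-2-methoxyphenyl in place of 2-cyanophenyl on an amine nitrogen in a ring.

The two steps that bear on this change are those in which the cyano of compound 1 was exchanged for another group on the same aromatic carbon. The 2,2,2-trifluoroethoxy exchange stayed within the scatter, whereas the phenyl exchange gave a modest loss. For the measured compounds named here, no measured step carries a hydroxy or methoxy group, so the present change is only loosely anchored. Since one of the two known exchanges cost nothing and the other cost a modest amount, compound 4 is expected to land somewhat above compound 1, with the step of a 2.5-fold higher number from compound 1 to compound 4 (0.40 log units; beyond the scatter) estimated as a small rise, possibly within the scatter. The expected value for compound 4 is 25 nM, with a range from 8 nM to 80 nM.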

Compound 4, dissociation constant: 79.4 nM
Compound 4: middle estimate off by 3.2-fold (0.50 log units), on the low side, and the stated range covers the measured number.
By their numbers in this assay, from the lowest: compounds 1 and 2 (each within the scatter of the next); then compounds 3 and 4 (each within the scatter of the next).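

In this assay, for the compounds shown here, the exchange of 2-cyanophenyl for 4-hydroxy-2-methoxyphenyl on an amine nitrogen in a ring gives a 7.9-fold higher number from compound 1 to compound 4 (0.90 log units; beyond the scatter) as a modest step beyond the scatter, and it is the first step here that replaces the whole aromatic group and brings in a hydrogen-bond donor. An oxygen-linked group on this aromatic ring therefore does not by itself keep the number near that of compound 1: the 2,2,2-trifluoroethoxy exchange gave a 1.6-fold higher number from compound 1 to compound 2 (0.20 log units; within the scatter) and stayed within the scatter, so the two oxygen-bearing compounds go different ways. No measurement among the data offered here accounts for the step.

The hydroxy and the methoxy enter together, and the nitrile leaves in the same change. The step cannot be divided between them. A phenyl group carrying only methoxy, or one carrying only hydroxy, would separate the two contributions, and an amine or a carboxylic acid in place of the hydroxy would show whether the outcome at this position depends on that group at all.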